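Deacetylation on the Longer Linker: An Expectation for Compound 4

The compounds below may be only part of what the source reports. "The series", "measured", "known", "first", "only" and "open" are said of these compounds alone.

Of the compounds shown here, three sharing one core have been measured in a functional assay on MCF7 cells (Homo sapiens) for inhibition, read by MTT assay, with a stated time of 48 h, tested at 10 uM; a higher number here means more inhibition at the concentration tested (going by the name of the read-out), a lower number less inhibition. In this assay compound 1 `COc1cc2cc(NC(C)=O)c(=O)oc2cc1OCCOc1no[n+]([O-])c1S(=O)(=O)c1ccccc1` gives 83.7%, compound 2 `COc1cc2cc(NC(C)=O)c(=O)oc2cc1OCCCOc1no[n+]([O-])c1S(=O)(=O)c1ccccc1` gives 88.5%, and compound 3 `COc1cc2cc(N)c(=O)oc2cc1OCCOc1no[n+]([O-])c1S(=O)(=O)c1ccccc1` gives 88.6%. Compound 3 arises from compound 1 by the change (hydrogen in place of acetyl on a nitrogen on an aromatic ring), and that step reads a number 4.9 percentage points higher from compound 1 to compound 3 (within the scatter). The difference between the core of compound 1 and the core of compound 2 is not broken down here. Compound 4 `COc1cc2cc(N)c(=O)oc2cc1OCCCOc1no[n+]([O-])c1S(=O)(=O)c1ccccc1` carries the same change relative to compound 2, namely (hydrogen in place of acetyl on a nitrogen on an aromatic ring). Since the earlier step from compound 1 to compound 3 stayed within the scatter, a step of similar size, a number 1.5 percentage points higher from compound 2 to compound 4 (within the scatter), is expected from compound 2 to compound 4. Compound 4 is therefore estimated to give 90% in this assay, with a range from 78% to 97%.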

Compound 4, a percentage reported as inhibition, at one concentration (the size of the read-out at that concentration, not a potency): 91.6%
The estimate for compound 4 lay 1.6 percentage points below the measured number; the range from low to high includes it.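

Moving the change from acetamido to amino onto the second core in this assay gives a number 3.1 percentage points higher from compound 2 to compound 4 (within the scatter). Set beside the earlier step, the change carries over between these two cores without a difference that can be told apart: the same change on two cores in this assay, a number 4.9 percentage points higher (within the scatter) from compound 1 to compound 3 and a number 3.1 percentage points higher (within the scatter) from compound 2 to compound 4, 1.8 percentage points apart, within the scatter of two such steps. Going by these compounds alone, this shows only that the two steps agree; since each lies within the scatter, it does not show that the change itself moves the read-out on either core, and it says nothing about cores beyond these two.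

The compounds shown leave open how a benzoyl or methanesulfonyl group would read on that nitrogen in place of acetyl. They also leave open whether the steps would agree on a longer chain between the core and the sulfonyl-bearing ring.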